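Compound 3: hydrogen in place of fluoro

The source may hold more compounds than are shown below. What is called first, only, known or untested is meant among the compounds shown, and "the series" means these compounds.

In a functional assay on a cell-free system (plasma, Homo sapiens), with a stated time of 3 min (a higher number here means a weaker inhibitor, a lower number a stronger inhibitor), compound 1 `CC(C)(C)OC[C@@H](O)C(=O)N1[C@H](C(=O)NCc2cc(Cl)ccc2-n2cnnn2)C[C@@H]2C[C@@H]21` gives 500 nM and compound 2 `O=C(NCc1cc(Cl)ccc1-n1cnnn1)[C@@H]1C[C@@H]2C[C@@H]2N1C(=O)[C@H](O)c1ccccc1F` gives 770 nM so that compound 2 stands within the scatter of compound 1. Compound 3 `O=C(NCc1cc(Cl)ccc1-n1cnnn1)[C@@H]1C[C@@H]2C[C@@H]2N1C(=O)[C@H](O)c1ccccc1` has hydrogen in place of fluoro on an aromatic carbon ortho to a large group. For the measured compounds named here, the only measured step of a 1.5-fold higher number from compound 1 to compound 2 (0.19 log units; within the scatter) is 2-fluorophenyl in place of (tert-butoxy)methyl and lies within the scatter. Going by the values given here, no measured step isolates the fluoro group. The expected step of a 1.1-fold lower number from compound 2 to compound 3 (0.04 log units; within the scatter) therefore stays within the scatter, with no favoured direction. Compound 3 is estimated at 700 nM with an expected range from 300 nM to 1700 nM in this series.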

Compound 3, half-maximal inhibitory concentration: 620 nM
Beside the measured number, compound 3's estimate is 1.1-fold (0.05 log units) above it, within the range that was stated.
By their numbers in this assay, from the lowest: compounds 1, 3 and 2 (each within the scatter of the next).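

In this assay the fluoro group is now read on its own: hydrogen in place of fluoro on an aromatic carbon ortho to a large group gives a 1.2-fold lower number from compound 2 to compound 3 (0.09 log units; within the scatter) and so does not separate the two compounds. Phenyl in place of (tert-butoxy)methyl gives a 1.2-fold higher number from compound 1 to compound 3 (0.09 log units; within the scatter) as well, so phenyl, like 2-fluorophenyl, cannot be told apart from the (tert-butoxy)methyl group. No evidence on the reason for these readings is available.

As far as these compounds go, whether an amine or a carboxylic acid on this aromatic carbon would move the number beyond the scatter stays open. The same holds for a longer chain in place of the phenyl.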